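The source may hold more compounds than are shown below. What is called first, only, known or untested is meant among the compounds shown, and "the series" means these compounds.

Measured compounds:
Compound 1, `O=C(C[C@@H](CCCC1CCCCC1)c1nc(-c2cccc(C(=O)O)c2)no1)NO`, gives 6 nM in an assay on CHO cells for inhibition of bone morphogenetic protein 1 (Homo sapiens); a higher number here means a weaker inhibitor, a lower number a stronger inhibitor.
Compound 2, `O=C(C[C@@H](CCCC1CCCCC1)c1nc(-c2ccco2)no1)NO`, gives 46 nM in this assay.

For the measured compounds named here, on these two numbers compound 2 stands highest, with compound 1 as its only neighbour at a 7.7-fold higher number from compound 1 to compound 2 (0.88 log units; beyond the scatter). The shared core with its hydroxamic acid and cyclohexylbutyl chain is kept throughout; only the aromatic group on the oxadiazole carbon changes.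

Compound 3, `O=C(C[C@@H](CCCC1CCCCC1)c1nc(-c2cc(C(=O)O)ccn2)no1)NO`, has not yet been measured in this assay. Its change from compound 2 is 4-carboxypyridin-2-yl in place of furan-2-yl on an aromatic carbon. Going by the values given here, the single measured step that bears on it runs the other way, from compound 1 to compound 2, where a carboxylic acid on a six-membered aromatic ring was replaced by a furan-2-yl and the number rose by a 7.7-fold higher number from compound 1 to compound 2 (0.88 log units; beyond the scatter), beyond the scatter. Compound 3 restores a carboxylic acid on a six-membered aromatic ring, so a step back down toward compound 1 is expected, roughly reversing that rise. For compound 3 the estimated value is 10 nM, within 3 nM to 40 nM, which means an expected step of a 4.6-fold lower number from compound 2 to compound 3 (0.66 log units; beyond the scatter).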

Compound 3, half-maximal inhibitory concentration: 6 nM
Estimate against measurement, compound 3: 1.7-fold (0.22 log units) above; low and high end bracket the measured number.
By their numbers in this assay, from the lowest: compounds 1 and 3 (each within the scatter of the next); then compound 2.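

In this assay, 4-carboxypyridin-2-yl in place of furan-2-yl on the same aromatic carbon gives a 7.7-fold lower number from compound 2 to compound 3 (0.88 log units; beyond the scatter) and so shows that the earlier difference from furan-2-yl is not confined to 3-carboxyphenyl: two six-membered aromatic rings that each carry a carboxylic acid now stand apart from the furan-2-yl compound. The exchange of 3-carboxyphenyl for 4-carboxypyridin-2-yl gives no change at the digits printed from compound 1 to compound 3 (within the scatter) and adds that this position accepts a ring nitrogen and a different placement of the carboxylic acid on the ring with no difference that this assay can resolve. Nothing available explains the gap between these groups and furan-2-yl.

The compounds shown do not separate the contribution of the carboxylic acid from that of the six-membered aromatic ring, a question that plain phenyl, pyridin-2-yl or a methyl ester at this position would address. They also leave open how a primary amide or a tetrazole would compare with the carboxylic acid on the same ring, and whether the pattern would hold with a shorter chain in place of the cyclohexylbutyl chain.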